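A few compounds are considered here, and "the series" means these few. Any claim that something is new, unique, unknown or untested is made for them only; others in the source may bear on it.

In a functional assay on MDA-MB-231 cells (Homo sapiens) for antiproliferative activity, read by CCK-8 assay, with a stated time of 48 h (a lower number here means a stronger inhibitor, a higher number a weaker inhibitor), two compounds built on the shared core have been measured so far. Compound 1 `COc1ccc(Nc2nc(Nc3cc(C)[nH]n3)cc(N3CCN(C)CC3)n2)cc1OC` gives 459 nM, while compound 2 `Cc1cc(Nc2cc(N3CCN(C)CC3)nc(Nc3ccc(F)c(Cl)c3)n2)n[nH]1` gives 95.5 nM, the lower of the two numbers. The step between them, with 3-chloro-4-fluorophenyl in place of 3,4-dimethoxyphenyl on a nitrogen on an aromatic ring, is a 4.8-fold lower number from compound 1 to compound 2 (0.68 log units; beyond the scatter).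

Compound 3 `Cc1cc(Nc2cc(N3CCN(C)CC3)nc(Nc3cccc(F)c3)n2)n[nH]1` has not yet been measured. It differs from compound 2 at that same place: 3-fluorophenyl in place of 3-chloro-4-fluorophenyl on a nitrogen on an aromatic ring. This puts 3-fluorophenyl in place of 3-chloro-4-fluorophenyl. Within the data shown here, only one measured step bears on the change, and only indirectly, since no measured pair shows this exchange alone. That step, a 4.8-fold lower number from compound 1 to compound 2 (0.68 log units; beyond the scatter), replaced a different group, and compound 3 keeps the phenyl ring and the fluorine of compound 2. A smaller step is therefore expected, with the number moving upward, and it may not clear the usual scatter. The expected change is a 1.7-fold higher number from compound 2 to compound 3 (0.22 log units; within the scatter). For compound 3 the estimated value is 160 nM, with an expected range of 60 nM to 420 nM.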

Compound 3, half-maximal inhibitory concentration: 166 nM
Compound 3: the middle estimate sits 1.0-fold (0.02 log units) below what was measured, within the range that was stated.
By their numbers in this assay, from the lowest: compounds 2 and 3 (each within the scatter of the next); then compound 1.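

In this assay, 3-fluorophenyl in place of 3-chloro-4-fluorophenyl on a nitrogen on an aromatic ring gives a 1.7-fold higher number from compound 2 to compound 3 (0.24 log units; within the scatter), so this position tolerates the exchange without a change that can be told from the scatter, even though the group that enters has one heavy atom fewer and no chlorine. The comparison with the 3,4-dimethoxyphenyl group gives a 2.8-fold lower number from compound 1 to compound 3 (0.44 log units; beyond the scatter), so the separation from compound 1 is now seen with two different halogen-bearing phenyl groups rather than one, and neither of these compounds goes against it. No measurement bearing on why these groups compare as they do is available here. As far as these compounds go, what a plain phenyl group, or a phenyl ring carrying a nitrile, a trifluoromethyl group or a lone chlorine, would give at this place remains open, so the part played by each substituent on the ring is not yet separated. All three compounds also share the rest of the core and a single cell-based read-out, which leaves open whether the same comparisons would hold with another group in place of the pyrazole-bearing amine or in other cells.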